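A fluoro replacement in a series held at the limit

The compounds below may be only part of what the source reports. "The series", "measured", "known", "first", "only" and "open" are said of these compounds alone.

Compound 1, `O=C(O)CC(NS(=O)(=O)c1ccccc1)c1ccccc1`: > 100000 nM, a limit
Compound 2, `O=C(O)CC(NS(=O)(=O)c1cccc([N+](=O)[O-])c1)c1ccccc1`: > 100000 nM, a limit
Compound 3, `O=C(O)CC(NS(=O)(=O)c1ccc(OC(F)(F)F)cc1)c1ccccc1`: > 100000 nM, a limit

All three compounds were tested in a functional assay on MDA-MB-231 cells (Homo sapiens) for antiproliferative activity, read by MTT assay, with a stated time of 24 h (on this read-out lower numbers stand for stronger inhibition and higher numbers for weaker inhibition), and none of them gave a number. Compound 1 stands at > 100000 nM, which is a limit of the assay. It shares that position with the other two, as the record shows: the limit of > 100000 nM in this assay, at which 3 of the 3 values shown sit.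

Compound 4, `O=C(O)CC(NS(=O)(=O)c1ccccc1)c1ccccc1F`, has not yet been measured. It departs from compound 1 by a single change: fluoro in place of hydrogen on an aromatic carbon. In words, this is fluoro in place of hydrogen on an aromatic carbon, ortho to a large group.

The nearest evidence comes from two other replacements of hydrogen on an aromatic carbon. One is a step that the two limits leave unreadable from compound 1 to compound 2. The other is a step that the two limits leave unreadable from compound 1 to compound 3. Neither step has a readable size, and neither ended in a number. On these two steps, no change of readable size is expected in this assay, in either direction. The expected step is a step that the limit leaves unreadable from compound 1 to compound 4. For compound 4 the estimated value is 120000 nM, with an expected range from 40000 nM to 300000 nM.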

Compound 4, half-maximal inhibitory concentration: > 100000 nM
Compound 4 ended at the assay's limit (the forecaster's own chance of this, stated with the estimate: 85%); the middle value is on the limit's open side.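

In this assay compound 4 gives > 100000 nM as a limit of the assay and not a number. No new step can be read from compound 1 to compound 4, and both compounds sit with compound 2 and compound 3 at the same position: the limit of > 100000 nM in this assay, at which 4 of the 4 values shown sit.

The compounds shown leave open what size, and what direction, any of these replacements has in this assay.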